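The source may hold more compounds than are shown below. What is called first, only, known or untested is meant among the compounds shown, and "the series" means these compounds.

For the measured compounds named here, in a functional assay on SMMC-7721 cells (Homo sapiens) for cytotoxicity, read by MTT assay, with a stated time of 72 h (on this read-out lower numbers stand for stronger inhibition and higher numbers for weaker inhibition), two compounds with a shared core have numbers so far. Compound 1 `COc1cccc(C=C2C(=O)N(c3ccc(Cl)cc3)N(c3ccc(Cl)cc3)C2=O)c1O` gives 64900 nM in this read-out, and compound 2 `COc1ccccc1C=C1C(=O)N(c2ccc(Cl)cc2)N(c2ccc(Cl)cc2)C1=O` gives 25800 nM as the lower of the two. The next compound, compound 3 `O=C1C(=Cc2ccco2)C(=O)N(c2ccc(Cl)cc2)N1c1ccc(Cl)cc1`, keeps the shared core and carries furan-2-yl in place of 2-methoxyphenyl on a double-bonded chain carbon bound to a double-bonded ring carbon, a change counted as furan-2-yl in place of 2-methoxyphenyl on a double-bonded chain carbon bound to a double-bonded ring carbon in full.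

Going by the values given here, only one measured step bears on this, a 2.5-fold lower number from compound 1 to compound 2 (0.40 log units; beyond the scatter) at the same place, where 2-methoxyphenyl replaced 2-hydroxy-3-methoxyphenyl. That step is modest. Among the compounds with values here, it alters a group on the benzene ring and does not replace the ring, and no measured compound carries furan-2-yl, so the direction is poorly fixed. Within the data shown here, a small rise is expected, no larger than that modest step, since compound 2 holds the lower of only two numbers. The estimated step is a 1.6-fold higher number from compound 2 to compound 3 (0.19 log units; within the scatter) and it may stay inside the usual scatter. Compound 3 is estimated at 40000 nM with an expected range from 14000 nM to 100000 nM in this assay once measured.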

Compound 3, half-maximal inhibitory concentration: 19500 nM
Compound 3: middle estimate off by 2.1-fold (0.31 log units), on the high side; low and high end bracket the measured number.
By their numbers in this assay, from the lowest: compounds 3 and 2 (each within the scatter of the next); then compound 1.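

In this assay, for the compounds shown here, this is the first time the ring itself was replaced at this place on a double-bonded chain carbon bound to a double-bonded ring carbon, with furan-2-yl, a five-membered aromatic ring with a hetero atom, taking the place of 2-methoxyphenyl, a six-membered aromatic ring of carbon only. The result is a 1.3-fold lower number from compound 2 to compound 3 (0.12 log units; within the scatter), so among these two compounds the read-out does not separate the two rings, and the smaller ring carries no measurable cost here. The comparison with the third compound gives a 3.3-fold lower number from compound 1 to compound 3 (0.52 log units; beyond the scatter), which leaves compound 1, with its 2-hydroxy-3-methoxyphenyl, apart from both compound 2 and compound 3, although nothing available accounts for any of these numbers.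

The compounds shown leave open how a thiophene or pyridine ring, a simple alkyl chain, or a benzene ring bearing an amine or a carboxylic acid would read at this place. All three also share the same core, so they leave open whether a change elsewhere on it would move the number further than any change at this place has so far.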